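Carboxy to carbamoyl on the aryl ether side chain

This account rests on a few compounds, and the source may have more. Where it says the series, first, only, none or still open, it means among the compounds named here.

Working notes on the series. Three measured compounds share one core and differ in the aryl group attached to it. Compound 1 `CCCn1c(=O)c2nc(-c3ccc(C(=O)NCC(=O)OC)cc3)[nH]c2n(CCC)c1=O` gives 38 nM in an assay on membranes from brain for antagonist activity at adenosine receptor A1 (Rattus norvegicus); on this read-out higher numbers stand for weaker inhibition and lower numbers for stronger inhibition. Compound 2 `CCCn1c(=O)c2[nH]c(-c3ccc(OC)cc3O)nc2n(CCC)c1=O` gives 4.6 nM in this assay. Compound 3 `CCCn1c(=O)c2nc(-c3ccc(OCC(=O)O)cc3O)[nH]c2n(CCC)c1=O` gives 37 nM in this assay.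

Where compound 3 stands: its number is the second highest of the three. Compound 1 lies within the scatter of compound 3, so no order can be read between those two. Compound 2 shows a lower number than compound 3, and that gap is beyond the scatter.

Compound 4 `CCCn1c(=O)c2nc(-c3ccc(OCC(N)=O)cc3O)[nH]c2n(CCC)c1=O` has not been measured. It differs from compound 3 by amino in place of hydroxy on a carbonyl carbon, read one bond further out as carboxy to carbamoyl. For the measured compounds named here, no measured pair shows this change, so the size of the step is not known from the data. The step of a 1.5-fold lower number from compound 3 to compound 4 (0.17 log units; within the scatter) is expected to be small, towards a lower number or none beyond the scatter. For compound 4 the estimated value in this assay is 25 nM, with a range from 8 nM to 80 nM.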

Compound 4, antagonist equilibrium constant in the adenosine receptor A1 assay: 6.5 nM
For compound 4 the middle estimate is 3.8-fold (0.59 log units) above the measured one; the measured number lies below the stated range.
By their numbers in the adenosine receptor A1 assay, from the lowest: compounds 2 and 4 (each within the scatter of the next); then compounds 3 and 1 (each within the scatter of the next).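

For the compounds shown here, in the adenosine receptor A1 assay, amino in place of hydroxy on a carbonyl carbon gives a 5.7-fold lower number from compound 3 to compound 4 (0.76 log units; beyond the scatter), the first step that can be read at a single place. The carboxymethoxy to carbamoylmethoxy change therefore registers on this read-out, although the two exchanged groups have the same printed counts of hydrogen-bond donors and acceptors. In a physicochemical assay for solubility, in the presence of a further agent that is not named here (on this read-out higher numbers stand for higher solubility and lower numbers for lower solubility), compound 3 gives 1100000 nM and compound 4 gives 5600000 nM. The same change also goes with higher solubility in the physicochemical assay: the measured solubility of compound 3, 1100000 nM, and of compound 4, 5600000 nM, a 5.1-fold higher number (0.71 log units; beyond the scatter)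

The compounds shown leave open whether the step in the adenosine receptor A1 assay is particular to the carbamoyl group or would also appear with a methyl ester or a nitrile at this place. They also leave open how a longer chain carrying the carbamoyl group would read in either assay.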